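A few compounds are considered here, and "the series" means these few. Any claim that something is new, unique, unknown or untested is made for them only; others in the source may bear on it.

In a functional assay on MDA-MB-231 cells (Homo sapiens) for inhibition (on this read-out higher numbers stand for weaker inhibition of growth and lower numbers for stronger inhibition of growth), compound 1 `Cc1cc(C)c2sc(NC(=O)c3ccc(C#N)cc3)nc2c1` gives 290 nM and compound 2 `O=C(CN1CCN(c2ccccc2)CC1)Nc1ccc(-c2nc3ccccc3s2)cc1` gives 200 nM. Among the compounds with values here, these two values lie within the scatter of each other, so compound 1 cannot be separated from the only other measured compound. The two structures do not differ in one place, which leaves the series without a measured step to use as a guide. Compound 3 `Cc1cc(C)c2sc(NC(=O)c3ccc([N+](=O)[O-])cc3)nc2c1` keeps the core of compound 1 and carries nitro in place of cyano on an aromatic carbon, para to a large group (nitro in place of cyano on an aromatic carbon). With nothing measured on this change, no shift beyond the scatter is expected in this assay, and no direction is favoured. The expected change is small, an estimated 1.0-fold higher number from compound 1 to compound 3 (0.01 log units; within the scatter). For compound 3 the estimated value is 300 nM, with an expected range of 100 nM to 900 nM.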

Compound 3, concentration for 50% growth inhibition: 290 nM
Compound 3: the middle estimate sits 1.0-fold (0.01 log units) above what was measured; low and high end bracket the measured number.
By their numbers in this assay, from the lowest: compounds 2, 1 and 3 (each within the scatter of the next).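

Nitro in place of cyano on an aromatic carbon, para to a large group, gives the series its first measured step, with no change at the digits printed from compound 1 to compound 3 (within the scatter) in this assay. At this place on the core of compound 1, the two groups therefore cannot be told apart on this read-out, even though nitro enters with one more heavy atom and one more hydrogen-bond acceptor than the cyano that leaves. No supporting measurement is available to explain this result.

Still open, as far as these compounds go, is whether an amine or a carboxylic acid at this place would give a step beyond the scatter. One step between two groups also leaves open how far the result extends to other groups or to changes elsewhere on the shared core.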